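The source may hold more compounds than are shown below. What is called first, only, known or untested is meant among the compounds shown, and "the series" means these compounds.

Measured compounds:
Compound 1, `CCOCc1cc(CN2CCCC2)c(O)c2ncccc12`, in a functional assay on MES-SA/Dx5 cells (Homo sapiens) for inhibition, with a stated time of 72 h (a lower number here means a stronger inhibitor, a higher number a weaker inhibitor), gives 912 nM.
Compound 2, `CCOCc1cc(CN2CCCCC2)c(O)c2ncccc12`, gives 776 nM.
Compound 3, `Oc1c(C(c2cccnc2)N2CCCC2)ccc2cccnc12`, gives 23400 nM.

Compound 1 and compound 2 share one core and differ in a single place: piperidin-1-yl in place of pyrrolidin-1-yl on a saturated chain carbon bound to an aromatic carbon. The step this made is a 1.2-fold lower number from compound 1 to compound 2 (0.07 log units; within the scatter), so the two compounds cannot be told apart by their half-maximal inhibitory concentrations. Compound 3 carries a different core; how its core differs from that of compound 1 is not broken down here. Its value stands as the highest of the three, well beyond the scatter from both compound 1 and compound 2.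

Compound 4, `Oc1c(C(c2cccnc2)N2CCCCC2)ccc2cccnc12`, has not yet been measured in this assay. It relates to compound 3 as compound 2 relates to compound 1: piperidin-1-yl in place of pyrrolidin-1-yl on a saturated chain carbon bound to two aromatic carbons. The place differs in its wording, a saturated chain carbon bound to two aromatic carbons rather than to one aromatic carbon, so this is the same kind of change, not the same change. Because the earlier instance gave a 1.2-fold lower number from compound 1 to compound 2 (0.07 log units; within the scatter), the step from compound 3 to compound 4 is expected to be small as well, around a 1.2-fold lower number from compound 3 to compound 4 (0.07 log units; within the scatter). On that basis compound 4 is estimated at 20000 nM, with a range from 8000 nM to 50000 nM, resting on a single prior example and so held loosely.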

Compound 4, half-maximal inhibitory concentration: 8510 nM
Estimate against measurement, compound 4: 2.4-fold (0.37 log units) above, within the range that was stated.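

Replacing pyrrolidin-1-yl with piperidin-1-yl on the core of compound 3 gives, in this assay, a 2.7-fold lower number from compound 3 to compound 4 (0.44 log units; beyond the scatter), a modest step that lies beyond the scatter, whereas the same change on the core of compound 1 stayed within it. Even so, the two steps cannot be told apart: the same change on two cores in this assay, a 1.2-fold lower number (0.07 log units; within the scatter) from compound 1 to compound 2 and a 2.7-fold lower number (0.44 log units; beyond the scatter) from compound 3 to compound 4, 2.3-fold (0.37 log units) apart, within the scatter of two such steps. Within the data shown here, this shows that, across these two cores, the change carried over without a detectable difference in the size of its step, but it rests on only two pairs and does not show that the step would be the same on any further core, nor that the change lowers the number in general.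

The compounds shown leave open how other amines on that saturated chain carbon, such as morpholin-4-yl or an open-chain dimethylamino group, would compare with pyrrolidin-1-yl and piperidin-1-yl on either core. They also leave open which part of the cores accounts for the higher numbers of compound 3 and compound 4, since no pair shown links the two cores through a single difference.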